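Aminoindazole series: benzylamine replaced by azetidinylmethylamine

The source may hold more compounds than are shown below. What is called first, only, known or untested is meant among the compounds shown, and "the series" means these compounds.

Measured so far in an assay for inhibition of Tryptophan 2,3-dioxygenase (Homo sapiens), with stated times of 10 min and 60 min; on this read-out lower numbers stand for stronger inhibition and higher numbers for weaker inhibition:
compound 1 `Oc1ccc(CNc2cc(C(F)(F)F)cc3[nH]ncc23)cc1` gives 2550 nM
compound 2 `Oc1ccc(CNc2cc(C(F)(F)F)cc3[nH]ncc23)c(Cl)c1` gives 2680 nM
compound 3 `O=[N+]([O-])c1ccc(Cl)cc1CNc1cc(C(F)(F)F)cc2[nH]ncc12` gives 3190 nM

Compound 1 stands at the lowest of the three numbers, but its neighbours sit close: the step of a 1.1-fold higher number from compound 1 to compound 2 (0.02 log units; within the scatter) is small, and the gap from compound 1 to compound 3 is likewise within the scatter, so the three compounds read as one level.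

Compound 4 `FC(F)(F)c1cc(NCC2CNC2)c2cn[nH]c2c1` has not been measured. It differs from compound 1 by azetidin-3-yl in place of 4-hydroxyphenyl on a saturated chain carbon bound to a nitrogen on an aromatic ring. Within the data shown here, no measured step covers this exchange; the only step on record, from compound 1 to compound 2, touches the aromatic ring that is now removed and was itself flat. The expectation for this assay therefore carries wide uncertainty, leaning toward a weaker number. For compound 4 the estimate is 4500 nM (range 1000 nM to 20000 nM), an expected step of a 1.8-fold higher number from compound 1 to compound 4 (0.25 log units; within the scatter).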

Compound 4, half-maximal inhibitory concentration: > 100000 nM
Compound 4: a limit, no number (the forecaster's own chance of this, stated with the estimate: 15%); middle value at least 22-fold (1.34 log units) away from the limit.
By their numbers in this assay, from the lowest: compounds 1, 2 and 3 (each within the scatter of the next). At a limit, above all of these: compound 4.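

Among these compounds, compound 1, compound 2 and compound 3 all carry an aromatic ring at this place and read as one level, so the earlier compounds showed only that its substituents can vary. In this assay, exchanging that ring gives an at least 39-fold higher number from compound 1 to compound 4 (1.59 log units; beyond the scatter), so this place does not tolerate every ring. Compound 4 stands at a limit, not a number: the limit of > 100000 nM in this assay, at which 1 of the 4 values shown sits.

As far as these compounds go, whether a cyclohexyl ring, an unsubstituted phenyl ring or a piperidine would hold the level of compound 1 remains open. The loss therefore cannot yet be tied to the missing aromatic ring or to the entering ring amine.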